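The compounds below may be only part of what the source reports. "The series", "measured", "known", "first", "only" and "open" are said of these compounds alone.

Three compounds have been measured in a functional assay on HeLa cells (Homo sapiens) for antiproliferative activity, read by MTT assay, with a stated time of 72 h; on this read-out higher numbers stand for weaker inhibition and lower numbers for stronger inhibition:
compound 1, `O=C1COc2ccc(-c3cnc(Cl)c(NS(=O)(=O)c4ccc(F)cc4)c3)cc2N1C1CCCCC1`, 14300 nM;
compound 2, `COc1ncc(-c2ccc3c(c2)N(c2ccc(Cl)cc2)C(=O)CO3)cc1NS(=O)(=O)c1ccc(F)cc1`, 4830 nM;
compound 3, `CC(C)N1C(=O)COc2ccc(-c3cccc(NS(=O)(=O)c4ccc(F)cc4)c3)cc21`, 22700 nM.

Compound 3 has the highest number of the three. Compound 1 lies nearest to it, with a number that sits within the usual scatter of that of compound 3. For the measured compounds named here, compound 2 lies furthest, with a number beyond the scatter below that of compound 3; compound 2 differs from compound 3 in more than one place, so no single step between the two is given.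

Compound 4, `Cc1ccc(N2C(=O)COc3ccc(-c4cccc(NS(=O)(=O)c5ccc(F)cc5)c4)cc32)cc1`, has not yet been measured in this assay. It differs from compound 3 in one place: 4-methylphenyl in place of isopropyl on an amide-type nitrogen in a ring. Going by the values given here, no measured pair isolates this change. Compound 2, which also carries a six-membered aromatic ring of carbon only on an amide-type nitrogen in a ring, gives 4830 nM, the lowest of the three numbers, but it differs from compound 3 elsewhere as well, so this is only a loose hint. A moderate step to a lower number is expected, a 2.5-fold lower number from compound 3 to compound 4 (0.40 log units; beyond the scatter), though it may stay within the scatter. Compound 4 is therefore estimated at 9000 nM, with a range from 3500 nM to 25000 nM.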

Compound 4, half-maximal inhibitory concentration: > 40000 nM
Compound 4: a limit, no number; the forecaster's own chance of this, stated with the estimate: 5%; at least 4.4-fold (0.64 log units) between middle value and limit.
By their numbers in this assay, from the lowest: compound 2; then compounds 1 and 3 (each within the scatter of the next). At a limit, above all of these: compound 4.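

In this assay compound 4 gives > 40000 nM, which is a limit of the assay and not a number. For the compounds shown here, this pair is the first to isolate a change on the amide-type nitrogen in a ring, and 4-methylphenyl in place of isopropyl there brings no lower number: the change gives an at least 1.7-fold higher number from compound 3 to compound 4 (0.24 log units; that floor lies within the scatter). How far the number actually rises cannot be told, since the reading rests on a value at the end of the measurable range: the limit of > 40000 nM in this assay, at which 1 of the 4 values shown sits.

The compounds shown leave open how this nitrogen would respond, on the core of compound 3, to a plain methyl, a chain ending in an amine or one ending in a carboxylic acid. They also leave open whether 4-methylphenyl would give a limit on the core of compound 1 or compound 2.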